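Pyridine attachment change in a cyanoguanidine antihypertensive series

The source may hold more compounds than are shown below. What is called first, only, known or untested is meant among the compounds shown, and "the series" means these compounds.

Measured so far:
compound 1, `CC(C)/N=C(\NC#N)Nc1cccnc1`: 2.5 mg/kg
compound 2, `CC(C)(C)C(C)(C)/N=C(\NC#N)Nc1cccnc1`: 50 mg/kg

In a functional assay on the whole organism (blood, strain Wistar-Okamoto) with Rattus norvegicus as the target, with a stated time of 5 days (a lower number here means that less compound is needed, a higher number that more compound is needed for the effect), compound 1 gives 2.5 mg/kg, while compound 2 gives 50 mg/kg. Among the measured compounds shown here, compound 2 therefore stands highest of the two numbers measured; the single recorded step, a 20-fold higher number from compound 1 to compound 2 (1.30 log units; beyond the scatter), separates it from compound 1. Compound 3, `CC(C)(C)C(C)(C)/N=C(\NC#N)Nc1ccncc1`, keeps the core of compound 2 and differs from it only in the change (pyridin-4-yl in place of pyridin-3-yl on an amine nitrogen). For the measured compounds named here, the one measured step concerns the saturated chain carbon and not the aromatic ring, so no measured step bears on this change, and how the pyridin-4-yl ring compares with the pyridin-3-yl ring is unknown. The expectation for compound 3 is therefore anchored on compound 2 with a wide range. Compound 3 is expected to give 50 mg/kg, with a range from 15 mg/kg to 170 mg/kg. The expected step of no change at the digits printed from compound 2 to compound 3 (within the scatter) is accordingly estimated to lie within the scatter.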

Compound 3, minimum effective dose: 20 mg/kg
Compound 3: the middle estimate sits 2.5-fold (0.40 log units) above what was measured, and the stated range covers the measured number.
By their numbers in this assay, from the lowest: compound 1; then compound 3; then compound 2.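

In this assay, among the compounds shown here, pyridin-4-yl in place of pyridin-3-yl on an amine nitrogen gives a 2.5-fold lower number from compound 2 to compound 3 (0.40 log units; beyond the scatter), the first measured step at the aromatic ring rather than the saturated chain carbon. The two groups have the same atoms and the same counted features, so the attachment of the ring alone moves the number beyond the scatter, although this remains the smaller of the two steps in the series, against a 20-fold higher number from compound 1 to compound 2 (1.30 log units; beyond the scatter). Nothing on hand accounts for this shift.

From the compounds shown here alone, the ring change is read on the chain of compound 2 only, so its size on the chain of compound 1 remains open. Also open, going by these compounds, is how a pyridin-2-yl or a phenyl ring on the same amine nitrogen would compare.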